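Series notes: sulfonyl replacing carbonyl at the amine nitrogen

The source may report more compounds than this note shows. Statements on the series, on what has been measured and on what is new or still open speak of the compounds shown alone.

Measured compounds:
compound 1, `CCCN(CC[C@H]1CC[C@H](NC(=O)/C=C/c2cccc(F)c2)CC1)[C@H]1CCc2nc(N)sc2C1`, giving 9.9 nM in an assay on brain for displacement of a labelled ligand from D(3) dopamine receptor (Rattus norvegicus); a lower number here means a stronger inhibitor, a higher number a weaker inhibitor
compound 2, `CCCN(CC[C@H]1CC[C@H](NC(=O)c2cccc3cnccc23)CC1)[C@H]1CCc2nc(N)sc2C1`, giving 5.9 nM
compound 3, `CCCN(CC[C@H]1CC[C@H](NC(=O)c2ccc(-n3cccn3)cc2)CC1)[C@H]1CCc2nc(N)sc2C1`, giving 3 nM

Compound 1 has the highest number of the three in this assay. Its nearest neighbour is compound 2 (a 1.7-fold lower number from compound 1 to compound 2 (0.22 log units; within the scatter)), its furthest compound 3 (a 3.3-fold lower number from compound 1 to compound 3 (0.52 log units; beyond the scatter)). The remaining step is also small (a 2.0-fold lower number from compound 2 to compound 3 (0.29 log units; within the scatter)).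

Compound 4, `CCCN(CC[C@H]1CC[C@H](NS(=O)(=O)c2ccc(OC)cc2)CC1)[C@H]1CCc2nc(N)sc2C1`, differs from compound 1 in one place: (4-methoxyphenyl)sulfonyl in place of (2-(3-fluorophenyl)ethenyl)carbonyl on an amine nitrogen. Going by the values given here, all three measured compounds keep a carbonyl at this amine nitrogen and vary only the ring attached to it, so no measured step bears directly on the exchange of carbonyl for sulfonyl; the measured steps show only that changing the group at this place has so far moved the number modestly. The change in compound 4 is larger in kind than any measured one, so a step beyond the scatter in either direction is plausible, with a weakening direction judged somewhat more likely. The expected step is a 2.5-fold higher number from compound 1 to compound 4 (0.40 log units; beyond the scatter). Compound 4 is therefore estimated at 25 nM, within a range from 5 nM to 120 nM.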

Compound 4, inhibition constant: 0.78 nM
The estimate for compound 4 lay 32-fold (1.51 log units) above the measured number; the measured number lies below the stated range.
By their numbers in this assay, from the lowest: compound 4; then compounds 3, 2 and 1 (each within the scatter of the next, the first and the last beyond it).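

In this assay, going by these compounds alone, this amine nitrogen accepts a sulfonyl in place of a carbonyl without loss of binding, with a 13-fold lower number from compound 1 to compound 4 (1.10 log units; beyond the scatter) as the largest step so far. A carbonyl at this nitrogen is therefore not needed for a low number, and this place can move the number further than the earlier changes among carbonyl-linked groups did. No data at hand explain the step.

The step exchanges the linking group and the attached group together, so the separate shares of the sulfonyl and the 4-methoxyphenyl remain unresolved. A 4-methoxybenzoyl on the same nitrogen would address the linker alone, while a methanesulfonyl would show how much of the attached aromatic ring the sulfonyl series needs.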